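This account rests on a few compounds, and the source may have more. Where it says the series, first, only, none or still open, it means among the compounds named here.

Measured in a functional assay on A-431 cells (Homo sapiens) for cytotoxicity; a lower number here means a stronger inhibitor, a higher number a weaker inhibitor:
Compound 1 `COc1cccc(NC(=N)c2cc(OC)c(OC)cc2N)c1`: 340000 nM
Compound 2 `COc1cc2c(cc1OC)C(Nc1cccc(Br)c1)=NC(C)(C)N2`: 130000 nM

Both numbers are high, and a lower number means a stronger inhibitor. Compound 2, at 130000 nM, has the lower number of the two, and its gap to compound 1 lies beyond the usual scatter. Compound 3 `COc1cccc(NC2=NC(C)(C)Nc3cc(OC)c(OC)cc32)c1` keeps the core of compound 2 and changes one group, with methoxy in place of bromo on an aromatic carbon, 3-bromophenyl to 3-methoxyphenyl: methoxy in place of bromo on an aromatic carbon.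

Among the compounds with values here, no measured pair shows this swap alone. Compound 1 does carry the 3-methoxyphenyl group and gives 340000 nM, but its core is different, so it is only a loose guide. A small step towards a higher number in this assay is expected, perhaps none beyond the scatter. The expected change is a 1.4-fold higher number from compound 2 to compound 3 (0.14 log units; within the scatter). For compound 3 the estimated value is 180000 nM, with an expected range from 70000 nM to 450000 nM.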

Compound 3, half-maximal inhibitory concentration: 320000 nM
For compound 3 the middle estimate is 1.8-fold (0.25 log units) below the measured one, and the stated range covers the measured number.
By their numbers in this assay, from the lowest: compound 2; then compounds 3 and 1 (each within the scatter of the next).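

In this assay the swap of bromo for methoxy on an aromatic carbon, meta to a large group, can now be read directly on one shared core, and it gives a 2.5-fold higher number from compound 2 to compound 3 (0.39 log units; beyond the scatter) as a modest move. This position therefore responds to the group it carries, with 3-bromophenyl giving the lower number of this pair, although both numbers remain high. Nothing available explains why this change moves the number.

The compounds shown leave open how other groups at this position, such as an amine, a carboxylic acid or a longer chain, would compare on the same core. They also leave open whether the same swap would give a similar step on the core of compound 1.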